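Methoxy to hydroxy on the trimethoxyphenyl hydrazone

A few compounds are considered here, and "the series" means these few. Any claim that something is new, unique, unknown or untested is made for them only; others in the source may bear on it.

In a physicochemical assay for lipophilicity, measured as octanol-water partition (on this read-out higher numbers stand for higher lipophilicity and lower numbers for lower lipophilicity), the three measured compounds stand as follows:

compound 1 `O=C(COc1cccc2ccccc12)N/N=C/C=C/c1ccccc1`: 4.43
compound 2 `COc1cc(/C=N/NC(=O)COc2cccc3ccccc23)cc(OC)c1OC`: 3.26
compound 3 `COc1ccc(/C=N/NC(=O)COc2cccc3ccccc23)cc1OC`: 3.51

Compound 2 has the lowest of the three numbers. Its nearest neighbour is compound 3, and the step of a number 0.25 log units higher from compound 2 to compound 3 (within the scatter) lies within the scatter. Compound 1 stands furthest away, with a value that is beyond the scatter above that of compound 2.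

Compound 4 `COc1cc(/C=N/NC(=O)COc2cccc3ccccc23)cc(OC)c1O` is not yet measured. It differs from compound 2 in one place: hydrogen in place of methyl on an oxygen on an aromatic ring, which, cut one bond further out, reads as methoxy to hydroxy. Within the data shown here, none of the measured steps carries this change; the only measured step, from compound 2 to compound 3, exchanges a methoxy for a hydrogen and was small, so it does not speak directly to a hydroxy in place of a methoxy. No measured pair shows a methyl leaving an oxygen, so the expectation rests on the change itself rather than on a shown step. The expected step of a number 0.46 log units lower from compound 2 to compound 4 (beyond the scatter) is downward and of modest size, likely at or just beyond the scatter. Compound 4 is therefore estimated at 2.8 in this assay, within a range from 2.4 to 3.2.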

Compound 4, partition coefficient: 3.23
For compound 4 the middle estimate is 0.43 log units below the measured one; measured number above the stated range.
By their numbers in this assay, from the lowest: compounds 4, 2 and 3 (each within the scatter of the next); then compound 1.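

In this assay, the exchange of methoxy to hydroxy on this aromatic ring keeps compound 4 within the scatter of compound 2: the step is a number 0.03 log units lower from compound 2 to compound 4 (within the scatter). Among these compounds, this is the first measured case of a methyl leaving an oxygen on the ring, and it shows that at this place, the loss of that one carbon does not move the read-out beyond the scatter, just as the step of a number 0.25 log units higher from compound 2 to compound 3 (within the scatter), where a methoxy gives way to hydrogen, stays within it. Nothing available gives a measured reason for this result, and the size of the step is reported here without any explanation.

The compounds shown leave open whether a longer chain on this same oxygen, such as an ethyl or butyl group, or an amine in place of the hydroxy, would also stay within the scatter of compound 2. They also leave open whether methoxy to hydroxy at either of the other two methoxy groups of compound 2 would give a step of similar size.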